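A cyclopentyl group replaces 2-methoxyethyl

The compounds below may be only part of what the source reports. "The series", "measured", "known", "first", "only" and "open" are said of these compounds alone.

In a functional assay on HT-29 cells (Homo sapiens) for inhibition, read by luminescence and CellTiter-Glo, with a stated time of 24 h (a higher number here means that more compound is needed for the effect, a lower number that less compound is needed), compound 1 `COCCn1nc(C(=O)N[C@H]2COc3ccccc3N(C)C2=S)nc1Cc1ccccc1` gives 566 nM, the second highest of three numbers. Compound 2 `CN1C(=S)[C@@H](NC(=O)c2nc(Cc3ccccc3)n(CCCCC#N)n2)COc2ccccc21` stands higher at 2680 nM, and compound 3 `CN1C(=S)[C@@H](NC(=O)c2nc(Cc3ccccc3)n(C3CCC3)n2)COc2ccccc21` stands lower at 181 nM. Compound 4 `CN1C(=S)[C@@H](NC(=O)c2nc(Cc3ccccc3)n(C3CCCC3)n2)COc2ccccc21`, not yet measured, carries cyclopentyl in place of 2-methoxyethyl on an aromatic nitrogen. The closest guide is the modest step of a 3.1-fold lower number from compound 1 to compound 3 (0.50 log units; beyond the scatter), where cyclobutyl enters at the same place. The large step of a 15-fold lower number from compound 2 to compound 3 (1.17 log units; beyond the scatter) also favours cyclobutyl, whereas the modest step of a 4.7-fold higher number from compound 1 to compound 2 (0.68 log units; beyond the scatter) runs the other way and involves no ring. A step of similar size toward a lower number is therefore expected in this assay, an estimated 2.8-fold lower number from compound 1 to compound 4 (0.45 log units; beyond the scatter). The estimate for compound 4 is 200 nM, with an expected range of 70 nM to 570 nM.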

Compound 4, half-maximal effective concentration: 3530 nM
For compound 4 the middle estimate is 18-fold (1.25 log units) below the measured one, and the stated range ends below it.
By their numbers in this assay, from the lowest: compound 3; then compound 1; then compounds 2 and 4 (each within the scatter of the next).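

In this assay the cyclobutyl result does not carry over to cyclopentyl: the two rings are separated by a 20-fold higher number from compound 3 to compound 4 (1.29 log units; beyond the scatter), and 2-methoxyethyl is the better of the pair with cyclopentyl, as a 6.2-fold higher number from compound 1 to compound 4 (0.79 log units; beyond the scatter) shows. Cyclopentyl also cannot be told apart from the open 4-cyanobutyl chain, with a 1.3-fold higher number from compound 2 to compound 4 (0.12 log units; within the scatter), so a ring on this aromatic nitrogen does not by itself give a low number. No measurement at hand accounts for this gap between the two rings. As far as these compounds go, what cyclopropyl or cyclohexyl would give on this nitrogen stays open, so cyclobutyl may be an isolated low point or part of a trend with ring size.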